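The compounds below may be only part of what the source reports. "The series", "measured", "known", "first", "only" and "open" are said of these compounds alone.

Of the compounds shown here, three from this series have been tested so far in an ADME assay on C8166 cells (Homo sapiens) for cytotoxicity, read by colorimetric assay and MTT assay; a higher number here means that more compound is tolerated, a lower number that less compound is tolerated. Compound 1 `Cc1ccc(C(=O)c2c(OCC(=O)Nc3ccc(S(N)(=O)=O)cc3C)ccc3ccccc23)cc1C` gives 33000 nM. Compound 2 `Cc1cccc(C(=O)c2c(OCC(=O)Nc3ccc(S(N)(=O)=O)cc3C)ccc3cc(C#N)ccc23)c1`, which carries a nitrile on the shared core and a 3-methylphenyl on the carbonyl carbon, gives 15200 nM. Compound 3 `Cc1cc(S(N)(=O)=O)ccc1NC(=O)COc1ccc2cc(C#N)ccc2c1C(=O)c1cccc(Cl)c1` is reported only as a limit of the assay, > 374000 nM, so its exact position is not known. That limit is the point at which one of the three values sits (the limit of > 374000 nM in this assay, at which 1 of the 3 values shown sits). Going by the values given here, the one measured step between neighbours, an at least 24-fold higher number from compound 2 to compound 3 (1.39 log units; beyond the scatter), shows that swapping methyl for chloro on the aromatic carbon of the phenyl group moved the number up past what the assay could resolve.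

Compound 4 `Cc1ccc(C(=O)c2c(OCC(=O)Nc3ccc(S(N)(=O)=O)cc3C)ccc3cc(C#N)ccc23)cc1C` has not yet been measured. It differs from compound 3 by 3,4-dimethylphenyl in place of 3-chlorophenyl on a carbonyl carbon. Among the compounds with values here, this step reverses the direction of the only measured step, since compound 3 holds the chloro that made compound 2 into compound 3, and compound 1 shows that a 3,4-dimethylphenyl on a related core gives a number near that of compound 2. Compound 4 is therefore expected to move back down from the limit, with an estimated value of 30000 nM, ranging from 10000 nM to 120000 nM, a step of an at least 12-fold lower number from compound 3 to compound 4 (1.09 log units; beyond the scatter).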

Compound 4, half-maximal cytotoxic concentration: > 379000 nM
Compound 4 gave a limit, no number; the forecaster's own chance of this, stated with the estimate: 20%; at least 12-fold (1.10 log units) between middle value and limit.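

In this assay compound 4 gives a limit of the assay and not a number: the limit of > 379000 nM in this assay, at which 1 of the 4 values shown sits.

A chloro on the phenyl group is therefore not the only way to reach the top of the measurable range, as one added methyl on an aromatic carbon gives an at least 24-fold higher number from compound 2 to compound 4 (1.39 log units; beyond the scatter). Going by these compounds alone, the nitrile on the shared core can now be read on its own for the first time, and cyano in place of hydrogen on an aromatic carbon gives an at least 11-fold higher number from compound 1 to compound 4 (1.06 log units; beyond the scatter).

On these data alone, the step between compound 3 and compound 4 cannot be read, as both compounds sit at limits, so it stays open which of 3-chlorophenyl and 3,4-dimethylphenyl on the carbonyl carbon allows more compound to be tolerated. Also open, as far as these compounds go, is what an amine or a carboxylic acid on that phenyl ring would do to the number, and whether any such group would bring it back into the range where a real value can be read.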